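Acyl chain extension on the thiophene-bearing core

The source may report more compounds than this note shows. Statements on the series, on what has been measured and on what is new or still open speak of the compounds shown alone.

Compound 2 `CC(=O)C1=C(C)NC(=O)NC1c1ccsc1` gives 9% in an assay on membranes from CHO cells for displacement of a labelled ligand from adenosine receptor A1 (Homo sapiens), read by scintillation counting, with a stated time of 60 min, tested at 1 uM; a lower number here means less inhibition, a higher number more inhibition at the concentration tested (going by the name of the read-out). Going by the values given here, compound 1 `CCCC(=O)C1=C(C)NC(=O)NC1c1ccoc1`, the only other measured member, gives 1% in this assay; the two readings lie within the scatter of each other, so compound 2 stands level with compound 1 and neither is set apart. Compound 3 `CCCC(=O)C1=C(C)NC(=O)NC1c1ccsc1` is not yet measured; against compound 2 it shows (ethyl in place of hydrogen on a saturated chain carbon bound to a carbonyl carbon). Among the compounds with values here, no measured pair isolates this change, and both readings so far are small. The step of a number 3 percentage points lower from compound 2 to compound 3 (within the scatter) is expected to be none beyond the scatter. Compound 3 is therefore estimated at 6%, within a range from 0% to 16%.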

Compound 3, a percentage reported as inhibition, at one concentration (the size of the read-out at that concentration, not a potency): 6%
Estimate against measurement, compound 3: no gap at the digits printed; the range from low to high includes it.
By their numbers in this assay, from the lowest: compounds 1, 3 and 2 (each within the scatter of the next).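

In this assay, ethyl in place of hydrogen on a saturated chain carbon bound to a carbonyl carbon gives a number 3 percentage points lower from compound 2 to compound 3 (within the scatter) and so does not set these two apart. Thiophen-3-yl in place of furan-3-yl on a saturated ring carbon gives a number 5 percentage points higher from compound 1 to compound 3 (within the scatter) and likewise separates neither member of the pair. No supporting data bear on either step.

All these readings remain small at the single concentration tested. Going by these compounds, whether a longer chain, an amine or a carboxylic acid at the chain position would move the reading beyond the scatter stays open.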